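A few compounds are considered here, and "the series" means these few. Any claim that something is new, unique, unknown or untested is made for them only; others in the source may bear on it.

Of the compounds shown here, three have been tested in a functional assay on Hs-578T cells (Homo sapiens) for inhibition, read by sulforhodamine B assay, with a stated time of 48 h; on this read-out lower numbers stand for higher toxicity in this test and higher numbers for lower toxicity in this test. Compound 1 `COc1cc(-c2cc(/C=C/C(=O)c3ccc(N)cc3)[nH]n2)cc(OC)c1OC` carries three methoxy groups on one aromatic ring. In this assay compound 1 gives only a limit of the test, > 100000 nM. Compound 2 `COc1ccc(-c2cc(/C=C/C(=O)c3ccc(N)cc3)[nH]n2)cc1OC` differs from compound 1 by hydrogen in place of methoxy on an aromatic carbon. In this assay compound 2 likewise gives only a limit, > 100000 nM. The step that the two limits leave unreadable from compound 1 to compound 2 cannot be read because of the limit of > 100000 nM in this assay, at which 3 of the 3 values shown sit. Compound 3 `COc1cc(C(=O)/C=C/c2cc(-c3cc(OC)c(OC)c(OC)c3)n[nH]2)cc(OC)c1OC` rests on a different core; how it differs from compound 1 is not broken down here. In this assay compound 3 gives only a limit, > 100000 nM. Within the data shown here, compound 4 `COc1ccc(-c2cc(/C=C/C(=O)c3cc(OC)c(OC)c(OC)c3)[nH]n2)cc1OC` has not yet been measured and differs from compound 3 by hydrogen in place of methoxy on an aromatic carbon, the same change as the one from compound 1 to compound 2, at a place described in the same words. Because (the limit of > 100000 nM in this assay, at which 3 of the 3 values shown sit), there is no measured case in which this change moved a compound below the limit. Compound 4 is therefore expected to give roughly 100000 nM in this assay. The expected step of a number no higher from compound 3 to compound 4 (the limit leaves the size open) is small, and a limit rather than a number seems likely.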

Compound 4, concentration lethal to 50% of the cells: > 100000 nM
Compound 4: no number, only a limit; the forecaster's own chance of this, stated with the estimate: 80%; the middle value sits exactly at the limit.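

In this assay compound 3 and compound 4 each give only a limit of the test and not a number, so the step between them, hydrogen in place of methoxy, cannot be read: (the limit of > 100000 nM in this assay, at which 4 of the 4 values shown sit). The compounds shown leave open what size this change would have in a compound that gives a real number.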